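This account rests on a few compounds, and the source may have more. Where it says the series, first, only, none or still open, it means among the compounds named here.

Values measured in a functional assay on L1210 cells (Mus musculus) for antiproliferative activity, with a stated time of 48 h; on this read-out lower numbers stand for stronger inhibition and higher numbers for weaker inhibition
- Compound 1 `C=C(Br)C(=O)Nc1ccc(/C=C/C(=O)c2ccc(I)cc2)cc1` with 3400 nM
- Compound 2 `Nc1ccc(/C=C/C(=O)c2ccc(Cl)cc2)cc1` with 111000 nM
- Compound 3 `Nc1ccc(/C=C/C(=O)c2ccc(Cl)c(Cl)c2)cc1` with 26000 nM

Compound 2 has the highest number of the three and so shows the weakest inhibition, with compound 3 the nearest to it. Compound 4 `Nc1ccc(/C=C/C(=O)c2ccc(I)cc2)cc1` has not yet been measured. It departs from compound 2 by iodo in place of chloro on an aromatic carbon and so has iodo in place of chloro on an aromatic carbon.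

Within the data shown here, only one measured step starts from compound 2. This is a 4.3-fold lower number from compound 2 to compound 3 (0.63 log units; beyond the scatter) and it is a modest move that came with chloro in place of hydrogen on an aromatic carbon. Among the measured compounds shown here, compound 1 also carries iodo, but it differs elsewhere too, so its 3400 nM gives no direct step for this swap.

On this thin evidence, a modest step towards a lower number is expected in this assay, though the direction is far from certain. The expected change is a 2.8-fold lower number from compound 2 to compound 4 (0.44 log units; beyond the scatter) as a rough estimate. Compound 4 is estimated at 40000 nM with an expected range from 12000 nM to 120000 nM for now.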

Compound 4, half-maximal inhibitory concentration: 50000 nM
Compound 4: middle estimate off by 1.3-fold (0.10 log units), on the low side; the measured number falls inside the stated range.
By their numbers in this assay, from the lowest: compound 1; then compounds 3 and 4 (each within the scatter of the next); then compound 2.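

In this assay, the step of a 2.2-fold lower number from compound 2 to compound 4 (0.35 log units; beyond the scatter) shows that the halogen on this aromatic carbon, para to a large group, can be exchanged with a measurable but modest effect, whereas the earlier step added a chloro in place of hydrogen and left the existing chloro unchanged. The step of a 15-fold higher number from compound 1 to compound 4 (1.17 log units; beyond the scatter) now isolates the change on the nitrogen, with hydrogen in place of (1-bromoethenyl)carbonyl, and this is a much larger step than the halogen exchange. Nothing measured here accounts for either step.

As far as these compounds go, how fluoro or a methoxy group would compare with chloro and iodo on this carbon remains open. So does whether a plain acetyl group on the nitrogen would give a value closer to that of compound 1 or compound 4.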